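A few compounds are considered here, and "the series" means these few. Any claim that something is new, unique, unknown or untested is made for them only; others in the source may bear on it.

Measured compounds:
compound 1 `CCOc1ccc(COc2c(OC)cc(/C=C/C(=O)OCC(=O)Nc3ccccc3)cc2OC)cc1` — > 200000 nM
compound 2 `O=C(COC(=O)/C=C/c1ccc(O)c(O)c1)NN1CCOCC1` — > 200000 nM
compound 3 `COc1ccc(NC(=O)COC(=O)/C=C/c2ccc(OCc3ccccc3)c(O)c2)cc1` — > 200000 nM

In a functional assay on CNE cells (Homo sapiens) for cytotoxicity, read by MTT assay, with a stated time of 72 h (on this read-out higher numbers stand for weaker inhibition and lower numbers for stronger inhibition), compound 2 gives > 200000 nM, which is a limit of the assay and not a number. Compound 1 gives > 200000 nM, again a limit. Compound 3 gives > 200000 nM, also a limit. Among the measured compounds shown here, every value shown therefore sits at the same boundary (the limit of > 200000 nM in this assay, at which 3 of the 3 values shown sit), so compound 2 cannot be placed relative to the other two: all three are indistinguishable on this read-out, and no step between measured compounds can be stated.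

Compound 4 `O=C(COC(=O)/C=C/c1ccc(O)c(O)c1)Nc1ccc(Cl)cc1` is the next member to be tested. It differs from compound 2 by 4-chlorophenyl in place of morpholin-4-yl on an amide-type nitrogen. Compound 3 already carries an aryl group on the corresponding amide nitrogen and stays at the limit, so the change from a morpholin-4-yl to a 4-chlorophenyl substituent gives no grounds to expect a move beyond the scatter in this assay; compound 4 is expected most likely to be reported as a limit as well. The estimated step from compound 2 to compound 4 is a step that the limit leaves unreadable from compound 2 to compound 4, that is, none that can be resolved. For compound 4 the estimate is 250000 nM, with a range from 80000 nM to 800000 nM.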

Compound 4, half-maximal inhibitory concentration: 89600 nM
Compound 4: the middle estimate sits 2.8-fold (0.45 log units) above what was measured, and the stated range covers the measured number.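

In this assay, among the compounds shown here, the amide-type nitrogen is the first place where a change can be read: 4-chlorophenyl in place of morpholin-4-yl gives an at least 2.2-fold lower number from compound 2 to compound 4 (0.34 log units; beyond the scatter). Compound 2 gives > 200000 nM, which is a limit of the assay, so this step has a floor but no known size, and the true distance between the two compounds may be larger. Compound 4 is also the only compound in the series so far with a value that is a number rather than a boundary, which gives later changes at this nitrogen a measured reference point instead of the limit that holds the rest of the series: the limit of > 200000 nM in this assay, at which 3 of the 4 values shown sit.

The pair swaps a non-aromatic ring with hetero atoms for a chlorinated aromatic ring in one move, so it cannot say whether the chlorine, the aromatic ring or the loss of the morpholine drives the step, and compounds 1 and 3 differ from compound 4 in more than one place and do not settle it. Open as well is how the same position responds to a 4-fluorophenyl, a 4-bromophenyl or a pyridin-4-yl ring, or to a benzyl group on this nitrogen, with the rest of compound 4 unchanged.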